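Azetidine in Place of Chlorine on the Pyridine

The source may hold more compounds than are shown below. What is called first, only, known or untested is meant among the compounds shown, and "the series" means these compounds.

Compound 3 `O=C(O)Cc1sc(C(c2ccc(F)cc2)c2ccc(F)cc2)nc1-c1ccnc(Cl)c1` carries a 2-chloropyridin-4-yl group on the shared core. In an in vitro assay on HEK385-7 cells for displacement of a labelled ligand from prostaglandin D2 receptor 2 (Homo sapiens) (on this read-out higher numbers stand for weaker inhibition and lower numbers for stronger inhibition), compound 3 gives 3.1 nM, the second highest of the three numbers measured. Its nearest neighbour is compound 2 `O=C(O)Cc1sc(C(c2ccc(F)cc2)c2ccc(F)cc2)nc1-c1ccnc(F)c1`, which in this assay gives 0.48 nM; the step of a 6.5-fold higher number from compound 2 to compound 3 (0.81 log units; beyond the scatter) is modest and beyond the scatter. Furthest away is compound 1 `N#Cc1ccc(-c2nc(C(c3ccc(F)cc3)c3ccc(F)cc3)sc2CC(=O)O)cc1`, which in this assay gives 150 nM; both a 48-fold lower number from compound 1 to compound 3 (1.68 log units; beyond the scatter) and a 310-fold lower number from compound 1 to compound 2 (2.49 log units; beyond the scatter) are large. Compound 4 `O=C(O)Cc1sc(C(c2ccc(F)cc2)c2ccc(F)cc2)nc1-c1ccnc(N2CCC2)c1` differs from compound 3 by azetidin-1-yl in place of chloro on an aromatic carbon. Within the data shown here, no measured step exchanges a halogen for a ring at this position; the only step at the same position, a 6.5-fold higher number from compound 2 to compound 3 (0.81 log units; beyond the scatter), swaps one halogen for another and does not carry over to an azetidin-1-yl group. The expectation is therefore uncertain and rests on compound 3 alone. Compound 4 is expected to give about 3 nM in this assay, within a range of 0.5 nM to 20 nM. The expected step is a 1.0-fold lower number from compound 3 to compound 4 (0.01 log units; within the scatter).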

Compound 4, half-maximal inhibitory concentration: 660 nM
Compound 4: the middle estimate sits 220-fold (2.34 log units) below what was measured, and the stated range ends below it.
By their numbers in this assay, from the lowest: compound 2; then compound 3; then compound 1; then compound 4.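

Among these compounds, at the carbon next to the ring nitrogen, the earlier compounds showed only one halogen exchanged for another; in this assay, putting azetidin-1-yl there gives a 210-fold higher number from compound 3 to compound 4 (2.33 log units; beyond the scatter) and a 1400-fold higher number from compound 2 to compound 4 (3.14 log units; beyond the scatter) and both steps are large, so this position tolerates the halogens far better than this ring. The pyridine also no longer gives a lower number than the 4-cyanophenyl group: compound 2 and compound 3 both lay well under compound 1, whereas the azetidine reverses that direction with a 4.4-fold higher number from compound 1 to compound 4 (0.64 log units; beyond the scatter) as a modest step. Nothing measured here explains the change.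

Going by these compounds, it remains open whether the rise follows the four-membered ring or the attached nitrogen. A dimethylamino group, a methoxy group or a pyrrolidin-1-yl group on the same carbon would bear on this.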